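The source may hold more compounds than are shown below. What is called first, only, known or untested is meant among the compounds shown, and "the series" means these compounds.

Compound 1 `Nc1nc2cc(Cl)c(Cl)cc2n1COC(CO)CO` is the reference point of this small series. In a functional assay on KB cells (Homo sapiens) for inhibition (a higher number here means a weaker inhibitor, a lower number a stronger inhibitor), compound 1 gives no number but only a limit of the assay, > 100000 nM. Compound 2 `CN(C)c1nc2c(Cl)cc(Cl)cc2n1COC(CO)CO` is a second measured member. In this assay compound 2 likewise returns only a limit, > 100000 nM. Compound 3 `OCC(CO)OCn1c(S)nc2c(Cl)c(Cl)ccc21` completes the measured set. In this assay compound 3 again yields only a limit, > 100000 nM. Among the measured compounds shown here, all three measured compounds therefore sit at the limit of > 100000 nM in this assay, at which 3 of the 3 values shown sit, so no step between measured compounds can be read from the numbers, and compound 1 has no ranking within the set beyond this shared limit. Compound 4 `OCC(CO)OCn1c(Br)nc2cc(Cl)c(Cl)cc21` is not yet measured. It differs from compound 1 by bromo in place of amino on an aromatic carbon. For the measured compounds named here, no measured step supports any direction for this change. The expected step from compound 1 to compound 4 is a step that the limit leaves unreadable from compound 1 to compound 4, that is none beyond the scatter. Compound 4 is therefore estimated at 150000 nM, in a range from 50000 nM to 500000 nM, most probably reported again only as a limit.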

Compound 4, half-maximal inhibitory concentration: > 100000 nM
Compound 4: only a limit was reported; the forecaster's own chance of this, stated with the estimate: 75%; the middle value does not contradict the limit.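

Bromo in place of amino gives no readable new step between compound 1 and compound 4 in this assay: the limit of > 100000 nM in this assay, at which 4 of the 4 values shown sit.

The compounds shown leave open whether any change on the shared core gives a measurable value in this assay, so the series has no ranking yet.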